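The source may report more compounds than this note shows. Statements on the series, on what has been measured and on what is new or still open speak of the compounds shown alone.

Of the compounds shown here, three sharing one core have been tested in a functional assay on HEK293 cells (Homo sapiens) for cytotoxicity; on this read-out lower numbers stand for higher toxicity in this test and higher numbers for lower toxicity in this test. Compound 1 (`COc1ccc([C@H]2CC(=O)N(c3ccc(C)c(N)c3)C2)cc1OC1CCCC1`) reads > 10000 nM, which is a limit and not a number. Compound 2 (`COc1ccc([C@H]2CC(=O)N(c3cccc(N)c3C)C2)cc1OC1CCCC1`) reads > 10000 nM, which is also a limit. Compound 3 (`COc1ccc([C@H]2CC(=O)N(c3ccc(N)cc3)C2)cc1OC1CCCC1`) reads > 10000 nM, again a limit. Compound 3 thus has no number of its own, and the whole set shares one reading: the limit of > 10000 nM in this assay, at which 3 of the 3 values shown sit.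

The next compound is compound 4 (`COc1ccc([C@H]2CC(=O)N(c3ccccc3C)C2)cc1OC1CCCC1`), and the structural change leading to it is 2-methylphenyl in place of 4-aminophenyl on an amide-type nitrogen in a ring. In words, 2-methylphenyl stands in place of 4-aminophenyl on an amide-type nitrogen in a ring.

Among the measured compounds shown here, three measured steps bear on this change, all made on that same nitrogen: a step that the two limits leave unreadable from compound 1 to compound 2, a step that the two limits leave unreadable from compound 1 to compound 3 and a step that the two limits leave unreadable from compound 2 to compound 3. None of them has a readable size, so they give no measured size or direction to carry over. Still, none of the three aryl groups tested there produced a value other than the limit. No step beyond the scatter is therefore expected in this assay, and the expected change is a step that the limit leaves unreadable from compound 3 to compound 4. Compound 4 is expected to read about 20000 nM, with an estimated range from 8000 nM to 50000 nM.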

Compound 4, half-maximal cytotoxic concentration: > 10000 nM
Compound 4: no number, only a limit (the forecaster's own chance of this, stated with the estimate: 85%); the middle value is on the limit's open side.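

In this assay compound 4 gives > 10000 nM, which is a limit and not a number. Its steps from compound 1, compound 2 and compound 3 cannot be read, and the set shares one reading: the limit of > 10000 nM in this assay, at which 4 of the 4 values shown sit.

The compounds shown leave open how far any of the four lies past this limit, and whether any group on the amide-type nitrogen would give a measurable value.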